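Swapping fluoro for chloro on a methylsulfonyl-bearing aniline

A few compounds are considered here, and "the series" means these few. Any claim that something is new, unique, unknown or untested is made for them only; others in the source may bear on it.

Of the compounds shown here, three have been measured in an assay for binding affinity to Alpha-1D adrenergic receptor (Homo sapiens), read by radioligand binding; a lower number here means a stronger inhibitor, a higher number a weaker inhibitor. Compound 1, `CS(=O)(=O)c1ccc(F)cc1NCC1=NCCN1`, gives 2630 nM in this assay. Compound 3, `CS(=O)(=O)c1ccc(Cl)cc1NCC1=NCCN1`, gives 2400 nM in this assay. Compound 2, `CS(=O)(=O)c1cc(F)ccc1NCC1=NCCN1`, is built from the same atoms as compound 1 joined differently; the difference between the two cores is not broken down here. In this assay compound 2 gives 1620 nM. All three values lie within the usual scatter of one another.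

Compound 1 and compound 3 differ by chloro in place of fluoro on an aromatic carbon, a change that gave a 1.1-fold lower number from compound 1 to compound 3 (0.04 log units; within the scatter). Compound 4, `CS(=O)(=O)c1cc(Cl)ccc1NCC1=NCCN1`, is not yet measured and relates to compound 2 by chloro in place of fluoro on an aromatic carbon. This is the same kind of change, but the surroundings differ: in compound 3 the chloro sits meta to a group of 7 heavy atoms and para to a methylsulfonyl group, while in compound 4 it sits meta to a methylsulfonyl group and para to a group of 7 heavy atoms. Because the earlier exchange a 1.1-fold lower number from compound 1 to compound 3 (0.04 log units; within the scatter) lay within the scatter, a step of similar size is expected from compound 2, namely a 1.1-fold lower number from compound 2 to compound 4 (0.03 log units; within the scatter). Compound 4 is therefore estimated at 1500 nM, most likely between 700 nM and 3200 nM.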

Compound 4, inhibition constant: 871 nM
The estimate for compound 4 lay 1.7-fold (0.24 log units) above the measured number; measured number inside the range.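

In this assay, putting chloro in place of fluoro on the core of compound 2 gave a 1.9-fold lower number from compound 2 to compound 4 (0.27 log units; within the scatter). Set beside the same exchange on the core of compound 1, the two steps cannot be told apart: the same change on two cores in this assay, a 1.1-fold lower number (0.04 log units; within the scatter) from compound 1 to compound 3 and a 1.9-fold lower number (0.27 log units; within the scatter) from compound 2 to compound 4, 1.7-fold (0.23 log units) apart, within the scatter of two such steps. Within these two pairs, then, the step seen on one core was a fair guide to the step on the other, but every step lies within the scatter, so this does not show that the exchange truly shifts the number on either core, nor that it would carry over to any further core.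

The compounds shown carry only fluoro or chloro at the changing place, so it remains open whether bromo, methoxy, trifluoromethyl or an amine there would give a step beyond the scatter. As far as these compounds go, it also remains open how the numbers would respond if the methylsulfonyl group gave way to a nitrile or a carboxylic acid.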